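A few compounds are considered here, and "the series" means these few. Any claim that something is new, unique, unknown or untested is made for them only; others in the source may bear on it.

Compound 1 `CC(C)=CCC/C(C)=C/CC/C(C)=C/CSc1ccccc1C(=O)N[C@@H](C)C(=O)OC(C)CCOc1no[n+]([O-])c1S(=O)(=O)c1ccccc1` gives 20400 nM in a functional assay on U-87MG ATCC cells (Homo sapiens) for cytotoxicity, read by MTT assay, with a stated time of 48 h; on this read-out higher numbers stand for weaker inhibition and lower numbers for stronger inhibition.
Compound 2 `CC(C)=CCC/C(C)=C/CC/C(C)=C/CSc1ccccc1C(=O)N[C@@H](C)C(=O)OCCOCCOc1no[n+]([O-])c1S(=O)(=O)c1ccccc1` gives 18100 nM in this assay.
Compound 3 `CC(C)=CCC/C(C)=C/CC/C(C)=C/CSc1ccccc1C(=O)NCC(=O)OC(C)CCOc1no[n+]([O-])c1S(=O)(=O)c1ccccc1` gives 15400 nM in this assay.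

All three numbers lie close together, and no one of them can be called stronger or weaker than another. Compound 3 differs from compound 1 in a single place: hydrogen in place of methyl on a saturated chain carbon bound to an amide-type nitrogen and a carbonyl carbon. That change gave a 1.3-fold lower number from compound 1 to compound 3 (0.12 log units; within the scatter), a step that does not rise above the ordinary spread of repeated measurements. Compound 2 carries the same amide-bearing side as compound 1 but a different core; the difference between the two cores is not broken down here.

Compound 4 `CC(C)=CCC/C(C)=C/CC/C(C)=C/CSc1ccccc1C(=O)NCC(=O)OCCOCCOc1no[n+]([O-])c1S(=O)(=O)c1ccccc1` has not yet been measured. It stands to compound 2 exactly as compound 3 stands to compound 1, the same change made at the same place: hydrogen in place of methyl on a saturated chain carbon bound to an amide-type nitrogen and a carbonyl carbon. Because the earlier step of a 1.3-fold lower number from compound 1 to compound 3 (0.12 log units; within the scatter) stayed within the usual scatter, the same change is expected here to give a step of similar, small size, a 1.2-fold lower number from compound 2 to compound 4 (0.08 log units; within the scatter). On that basis compound 4 is estimated at 15000 nM in this assay, most likely between 7500 nM and 30000 nM.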

Compound 4, half-maximal inhibitory concentration: 7340 nM
For compound 4 the middle estimate is 2.0-fold (0.31 log units) above the measured one, outside the stated range (below it).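

In this assay, putting hydrogen in place of the methyl on the core of compound 2 gives a 2.5-fold lower number from compound 2 to compound 4 (0.39 log units; beyond the scatter), a modest step that, unlike the earlier one, rises above the ordinary spread of repeated measurements. This does not show that the core changes the effect of the swap, and two pairs of compounds cannot show how the swap would behave on any further core. As far as these data can tell, the change carries from one core to the other with a size that cannot be told apart, since the gap between the two steps is no larger than the scatter expected for such a comparison: the same change on two cores in this assay, a 1.3-fold lower number (0.12 log units; within the scatter) from compound 1 to compound 3 and a 2.5-fold lower number (0.39 log units; beyond the scatter) from compound 2 to compound 4, 1.9-fold (0.27 log units) apart, within the scatter of two such steps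

The compounds shown leave open what other groups at this same place would do, such as an ethyl group, a longer chain, or a chain carrying an amine or a carboxylic acid. They also leave open whether a larger group there would move the number at all.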